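The compounds below may be only part of what the source reports. "The series", "measured", "known", "first", "only" and "open" are said of these compounds alone.

Measured compounds, cytotoxicity read-out:

compound 1, `CCCCCCCCCO[C@@H]1[C@@H](N)[C@@H](OCC(O)CNCCN)O[C@H](CN)[C@H]1OCCCCCCCCC`: 87.5%
compound 2, `CCCCCCCCCO[C@@H]1[C@@H](N)[C@@H](O[C@H]2[C@H](O)[C@@H](OCCCCCCCCC)[C@H](N)C[C@@H]2N)O[C@H](CN)[C@H]1O`: 78.4%
compound 3, `C=CCO[C@H]1O[C@H](CN)[C@@H](O)[C@H](O)[C@H]1N`: 82.2%

All three numbers come from a toxicity assay on the whole organism (J774 cells) for cytotoxicity, with Mus musculus as the target, read by MTT assay, with a stated time of 24 h, tested at 10 uM; on this read-out higher numbers stand for a weaker effect at the one concentration tested and lower numbers for a stronger effect. Compound 1 shows the highest number of the three, yet its gaps to compound 3 and to compound 2 both fall within the usual scatter of this read-out, so the three compounds read as a single level in this assay and no order among them can be drawn from the data.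

Compound 4, `CCCCCCCCCO[C@@H]1[C@@H](N)[C@@H](OC[C@H](O)CN)O[C@H](CN)[C@H]1OCCCCCCCCC`, is not yet measured. Against compound 1 the change is 2-amino-1-hydroxyethyl in place of 2-((2-aminoethyl)amino)-1-hydroxyethyl on a saturated chain carbon bound to an oxygen on a saturated carbon. The shared core and both nonyl chains of compound 1 are kept; only the side chain on the saturated chain carbon bound to an oxygen on a saturated carbon is shortened to 2-amino-1-hydroxyethyl.

Among the compounds with values here, no pair of measured compounds differs in one place, so there is no measured step to lean on. The three measured values sit within the scatter of one another, and nothing in them points to a move in either direction. Compound 4 is therefore expected to give 85% in this assay, with a range from 72% to 98%. The step of a number 2.5 percentage points lower from compound 1 to compound 4 (within the scatter) is expected to stay within the scatter, with no direction beyond it.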

Compound 4, a percentage reported as activity, at one concentration (the size of the read-out at that concentration, not a potency): 88%
For compound 4 the middle estimate is 3 percentage points below the measured one; measured number inside the range.
By their numbers in this assay, from the lowest: compounds 2, 3, 1 and 4 (each within the scatter of the next).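

The series now holds one step at a single place: in this assay, 2-amino-1-hydroxyethyl in place of 2-((2-aminoethyl)amino)-1-hydroxyethyl on a saturated chain carbon bound to an oxygen on a saturated carbon gives a number 0.5 percentage points higher from compound 1 to compound 4 (within the scatter). With the shared core and both nonyl chains held constant, this read-out therefore registers no change from shortening the side chain at this place. No measurement available here offers a cause for this result.

Still open, from the compounds shown here alone, is whether a different group at this place, such as a carboxylic acid or a guanidine, would take the number in this assay beyond the scatter. The single tested concentration also leaves open whether this side-chain change would matter at higher concentrations.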